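Phenyl in place of 4-methoxyphenyl: expectation for compound 4

This account rests on a few compounds, and the source may have more. Where it says the series, first, only, none or still open, it means among the compounds named here.

Three compounds of the series carry measurements in a physicochemical assay, read by spectrophotometry, with a stated time of 10 min; a lower number here means that less compound is needed, a higher number that more compound is needed for the effect. Compound 1 `CCOC(=O)C1=C(C[Se]C(=O)c2ccc(C)cc2)N(C)C(=O)NC1c1cccc([N+](=O)[O-])c1` gives 32800 nM, compound 2 `CCOC(=O)C1=C(C[Se]C(=O)c2ccc(C)cc2)NC(=O)NC1c1ccc(N(C)C)cc1` gives 29600 nM, and compound 3 `CCOC(=O)C1=C(C[Se]C(=O)c2ccc(C)cc2)NC(=O)NC1c1ccc(OC)cc1` gives 22500 nM. Compound 3 has the lowest number of the three, yet all three lie within the scatter of one another. Among the measured compounds shown here, the only single-site step, a 1.3-fold lower number from compound 2 to compound 3 (0.12 log units; within the scatter), is within the scatter. Compound 4 `CCOC(=O)C1=C(C[Se]C(=O)c2ccc(C)cc2)NC(=O)NC1c1ccccc1` differs from compound 3 by hydrogen in place of methoxy on an aromatic carbon. For the measured compounds named here, no measured step removes a group from that ring altogether; the one change at that ring, from compound 2 to compound 3, stayed within the scatter, so no step beyond the scatter in this assay is expected in either direction. Compound 4 is estimated at 25000 nM, with a range from 12000 nM to 50000 nM. The expected step is a 1.1-fold higher number from compound 3 to compound 4 (0.05 log units; within the scatter).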

Compound 4, half-maximal effective concentration: 10500 nM
For compound 4 the middle estimate is 2.4-fold (0.38 log units) above the measured one, outside the stated range (below it).
By their numbers in this assay, from the lowest: compound 4; then compounds 3, 2 and 1 (each within the scatter of the next).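

In this assay hydrogen on this aromatic carbon gives a 2.1-fold lower number from compound 3 to compound 4 (0.33 log units; beyond the scatter) and a 2.8-fold lower number from compound 2 to compound 4 (0.45 log units; beyond the scatter) as the first steps beyond the scatter among the compounds shown, both modest. The exchange of dimethylamino for methoxy at the same place stayed within the scatter, so the ring without a group here stands apart from compound 2 and compound 3. Nothing available explains this result.

On these data alone, whether a small group such as fluorine or methyl would side with compound 4 or with compound 3 remains open. Also open, as far as these compounds go, is whether the gain from hydrogen here persists when the ethyl ester is replaced by a carboxylic acid.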